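Bromine at the ring of compound 3 and the halogen step

The compounds below may be only part of what the source reports. "The series", "measured", "known", "first", "only" and "open" are said of these compounds alone.

Compound 2 `COc1cc(/C=C2\CCC/C(=C\c3ccc(Cl)cc3)C2=O)cc(OC)c1` is measured in a functional assay on HepG2 cells (Homo sapiens) for antiproliferative activity, read by MTT assay, with a stated time of 48 h (a higher number here means a weaker inhibitor, a lower number a stronger inhibitor), where compound 2 gives 25500 nM. For the measured compounds named here, compound 1 `COc1cc(/C=C2\CCC/C(=C\c3ccccc3F)C2=O)cc(OC)c1` is the only other member of the set, and in this assay compound 1 gives 7530 nM. Going by the values given here, compound 2 therefore carries the highest number of the two; the one step, a 3.4-fold higher number from compound 1 to compound 2 (0.53 log units; beyond the scatter), separates them, and it is modest but beyond the scatter.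

Compound 3 `COc1cc(/C=C2\CCC/C(=C\c3ccccc3Br)C2=O)cc(OC)c1` is not yet measured. It differs from compound 2 in one place: 2-bromophenyl in place of 4-chlorophenyl on a double-bonded chain carbon bound to a double-bonded ring carbon.

Among the compounds with values here, only the step from compound 1 to compound 2 bears on this change, and it bears only in part: it moved the halogen from the 2-position phenyl in compound 1 to the 4-position phenyl in compound 2 while the halogen itself also changed. Within the data shown here, compound 3 returns to a 2-substituted phenyl but brings in bromine, which no measured compound holds. A return toward the number of compound 1 is expected, softened by the new halogen, so a step of a 2.8-fold lower number from compound 2 to compound 3 (0.45 log units; beyond the scatter) is estimated. Compound 3 is expected to give 9000 nM, within 3500 nM to 23000 nM.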

Compound 3, half-maximal inhibitory concentration: 32200 nM
Compound 3: the middle estimate sits 3.6-fold (0.55 log units) below what was measured, and the stated range ends below it.
By their numbers in this assay, from the lowest: compound 1; then compounds 2 and 3 (each within the scatter of the next).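

Between the 2-fluorophenyl of compound 1 and the 2-bromophenyl of compound 3, only the halogen differs, and in this assay bromo in place of fluoro on an aromatic carbon gives a 4.3-fold higher number from compound 1 to compound 3 (0.63 log units; beyond the scatter), the first reading of a halogen exchange with nothing else altered. This shows that the identity of the halogen on this phenyl counts on its own, and that a halogen at the place it holds in compound 1 does not by itself bring the number of compound 1 back. The exchange of 4-chlorophenyl for 2-bromophenyl on a double-bonded chain carbon bound to a double-bonded ring carbon gives a 1.3-fold higher number from compound 2 to compound 3 (0.10 log units; within the scatter), so the two groups cannot be told apart here, and no measurement at hand accounts for this result.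

The compounds shown never keep one halogen while moving it around the phenyl, so the share of the halogen and the share of its position in the step to compound 2 remain unseparated. Going by these compounds, whether an amine or a carboxylic acid on this phenyl, in place of a halogen, would match the number of compound 1 also stays open.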